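The source may hold more compounds than are shown below. What is called first, only, known or untested is meant among the compounds shown, and "the series" means these compounds.

Measured so far:
compound 1 `COc1ccc(S(=O)(=O)Nc2cccc(I)c2)cc1N1CCNCC1` — 0.501 nM
compound 2 `COc1ccc(S(=O)(=O)Nc2cc(Br)cc(Br)c2)cc1N1CCNCC1` — 0.501 nM

In an assay on isolated protein for binding affinity to 5-hydroxytryptamine receptor 6 (Homo sapiens) (a higher number here means a weaker inhibitor, a lower number a stronger inhibitor), compound 2 stands level with compound 1: the step of no change at the digits printed from compound 1 to compound 2 (within the scatter) lies within the scatter. Compound 3 `COc1ccc(S(=O)(=O)Nc2cc(Br)cc(Br)c2F)cc1N1CCNCC1` carries fluoro in place of hydrogen on an aromatic carbon on the same ring. No measured step changes a hydrogen for fluoro; the only step available, no change at the digits printed from compound 1 to compound 2 (within the scatter), alters the halogen pattern on this ring without effect, so the series has shown itself tolerant there. The expected step of a 1.0-fold lower number from compound 2 to compound 3 (0.00 log units; within the scatter) is therefore none beyond the scatter. Compound 3 is estimated at 0.5 nM, with a range from 0.2 nM to 1.5 nM.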

Compound 3, inhibition constant: 2.51 nM
Compound 3: the middle estimate sits 5.0-fold (0.70 log units) below what was measured; the measured number lies above the stated range.
By their numbers in this assay, from the lowest: compounds 1 and 2 (each within the scatter of the next); then compound 3.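

In this assay the ring on the sulfonamide nitrogen is less tolerant than the halogen exchange suggested: fluoro in place of hydrogen, ortho to a bromo group and para to a bromo group, gives a 5.0-fold higher number from compound 2 to compound 3 (0.70 log units; beyond the scatter) and a step beyond the scatter. The 3,5-dibromo-2-fluorophenyl group likewise gives a 5.0-fold higher number from compound 1 to compound 3 (0.70 log units; beyond the scatter) against 3-iodophenyl, a step beyond the scatter. No measured evidence bears on the origin of this step.

On these data alone, whether chloro, methyl or methoxy at this carbon gives a similar step remains open. So does whether fluoro at this place has the same size of effect on the 3-iodophenyl ring.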